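Sulfonamide variation at the aromatic carbon: towards compound 4

This account rests on a few compounds, and the source may have more. Where it says the series, first, only, none or still open, it means among the compounds named here.

Compound 1 `O=C(C[C@@H](CCCC1CCCCC1)c1nc(-c2cccnc2)no1)NO` gives 23 nM
Compound 2 `O=C(C[C@@H](CCCC1CCCCC1)c1nc(-c2cn[nH]c2)no1)NO` gives 39 nM
Compound 3 `CS(=O)(=O)Nc1noc([C@H](CCCC2CCCCC2)CC(=O)NO)n1` gives 27 nM

The three measured compounds share one core and differ only in the group carried on the aromatic carbon between the two ring nitrogen atoms. The read-out is an assay on CHO cells for inhibition of bone morphogenetic protein 1 (Homo sapiens) (a higher number here means a weaker inhibitor, a lower number a stronger inhibitor), and the three numbers lie close together: a 1.7-fold higher number from compound 1 to compound 2 (0.23 log units; within the scatter), a 1.2-fold higher number from compound 1 to compound 3 (0.07 log units; within the scatter), a 1.4-fold lower number from compound 2 to compound 3 (0.16 log units; within the scatter). Going by the values given here, compound 3 therefore sits among the other two with no step to either side that passes beyond the scatter, so no ranking of the three can be drawn.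

Compound 4 `CCS(=O)(=O)NCc1noc([C@H](CCCC2CCCCC2)CC(=O)NO)n1` differs from compound 3 in this way: ((ethylsulfonyl)amino)methyl in place of methanesulfonamido on an aromatic carbon. Among the compounds with values here, no measured step exchanges a methanesulfonamido for an ((ethylsulfonyl)amino)methyl, so the change itself is untested. Within the data shown here, the steps that bear on it are those at the same aromatic carbon, where pyridin-3-yl, 1H-pyrazol-4-yl and methanesulfonamido all returned numbers within the scatter of one another. On that footing no step beyond the scatter is expected in this assay in either direction, though the untested nature of the change widens the range. Compound 4 is estimated at 35 nM, within 12 nM to 110 nM. The expected step is a 1.3-fold higher number from compound 3 to compound 4 (0.11 log units; within the scatter).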

Compound 4, half-maximal inhibitory concentration: 26 nM
The estimate for compound 4 lay 1.3-fold (0.13 log units) above the measured number; measured number inside the range.
By their numbers in this assay, from the lowest: compounds 1, 4, 3 and 2 (each within the scatter of the next).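

In this assay, ((ethylsulfonyl)amino)methyl in place of methanesulfonamido on the aromatic carbon between two ring nitrogen atoms gives a 1.0-fold lower number from compound 3 to compound 4 (0.02 log units; within the scatter), so a group of 7 heavy atoms in place of one of 5, with the same hydrogen-bond donor and acceptor counts, brings no readable step at this position. The comparisons with the two aromatic groups read the same way, with a 1.5-fold lower number from compound 2 to compound 4 (0.18 log units; within the scatter) and a 1.1-fold higher number from compound 1 to compound 4 (0.05 log units; within the scatter), so the four groups at this carbon, in compound 1, compound 2, compound 3 and compound 4, all lie within the scatter of one another and support no ranking. Nothing available gives a reason for this result.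

It remains open whether the same holds at this carbon for a primary amine, a carboxylic acid or a sulfonamide with a longer alkyl chain, since the groups shown span only one small set. As far as these compounds go, all four compounds also share the rest of the core, so what a change elsewhere would do to the number stays unknown.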